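This account rests on a few compounds, and the source may have more. Where it says the series, first, only, none or still open, it means among the compounds named here.

Measured compounds:
Compound 1 `CCc1cc(S(=O)(=O)N2C[C@H](c3ccccc3)NC2=O)ccc1NC(=O)OC(C)C`: 60 nM in a functional assay on NCI-H460 cells (Homo sapiens) for cytotoxicity, read by MTT assay; a lower number here means a stronger inhibitor, a higher number a weaker inhibitor.
Compound 2 `CC1[C@H](c2ccccc2)NC(=O)N1S(=O)(=O)c1ccc(NC(=O)c2ccc(N)cc2)c(Cl)c1`: > 10000 nM in this assay, which is a limit of the assay and not a number.

Among the compounds with values here, compound 1 holds the only number in this assay. The value of compound 2 is a limit, (the limit of > 10000 nM in this assay, at which 1 of the 2 values shown sits). Compound 3 `CCCOC(=O)Nc1ccc(S(=O)(=O)N2C[C@H](c3ccccc3)NC2=O)cc1CC` is not yet measured and differs from compound 1 by propyl in place of isopropyl on an oxygen next to a carbonyl group. Within the data shown here, no step between two measured compounds exists to guide the expectation, so it rests on compound 1 alone. The change is expected to produce no step beyond the usual scatter; the expected step is a 1.3-fold higher number from compound 1 to compound 3 (0.12 log units; within the scatter). Compound 3 is therefore expected to give 80 nM, within a range from 30 nM to 250 nM.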

Compound 3, half-maximal inhibitory concentration: 60 nM
Compound 3: middle estimate off by 1.3-fold (0.12 log units), on the high side, and the stated range covers the measured number.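

Within the data shown here, on an oxygen next to a carbonyl group, propyl in place of isopropyl gives no change at the digits printed from compound 1 to compound 3 (within the scatter) in this assay, the first step that can be read at this position. At this place, then, the straight chain and the branched chain of the same size cannot be told apart in this read-out. Nothing measured here gives a reason for this outcome. On these data alone, whether a longer chain such as hexyl, or a benzyl group, would fare the same on this oxygen stays open. This single pair says nothing about groups of any other size.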